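Chain ester variations on a sulfonylcarbamate biphenyl series

The source may report more compounds than this note shows. Statements on the series, on what has been measured and on what is new or still open speak of the compounds shown alone.

Measured so far:
compound 1 `CCCc1nc(CC)c(C(=O)OCCCOCc2ccccc2)n1Cc1ccc(-c2ccccc2S(=O)(=O)NC(=O)OCCC(C)C)cc1F` — 2 nM
compound 2 `CCCc1nc(CC)c(C(=O)NCCCOc2ccccc2)n1Cc1ccc(-c2ccccc2S(=O)(=O)NC(=O)OCCC(C)C)cc1F` — 9 nM
compound 3 `CCCc1nc(CC)c(C(=O)OCCN2C(=O)c3ccccc3C2=O)n1Cc1ccc(-c2ccccc2S(=O)(=O)NC(=O)OCCC(C)C)cc1F` — 7 nM

All three share the same core and differ only in the group on the carbonyl carbon. In an assay on isolated protein for binding affinity to Type-2 angiotensin II receptor (Homo sapiens) (on this read-out higher numbers stand for weaker inhibition and lower numbers for stronger inhibition), compound 3 gives 7 nM and stands second highest of the three numbers; its nearest neighbour is compound 2, within the scatter, and its furthest is compound 1, beyond it. The step of a 3.5-fold higher number from compound 1 to compound 3 (0.54 log units; beyond the scatter) shows that exchanging the benzyloxy-bearing chain for the phthalimide-bearing one costs a modest amount of affinity. The unmeasured compound 4 `CCCc1nc(CC)c(C(=O)OCCCCOc2ccccc2)n1Cc1ccc(-c2ccccc2S(=O)(=O)NC(=O)OCCC(C)C)cc1F` carries a group of 9 heavy atoms (8 carbon, 1 oxygen; one six-membered aromatic ring of carbon only) in place of a group of 11 heavy atoms (8 carbon, 1 nitrogen, 2 oxygen; one five-membered non-aromatic ring with 1 hetero atom, one six-membered aromatic ring of carbon only), on a saturated chain carbon, two bonds along the chain from an oxygen next to a carbonyl group. Going by the values given here, this change largely undoes the one between compound 1 and compound 3: a group of the same size and atom count as in compound 1 returns, only with the chain oxygen set differently. The step of a 4.5-fold higher number from compound 1 to compound 2 (0.65 log units; beyond the scatter) concerns the amide and bears less directly. A modest fall in the number is therefore expected, a 2.3-fold lower number from compound 3 to compound 4 (0.37 log units; beyond the scatter), bringing compound 4 close to compound 1. Compound 4 is estimated at 3 nM, within 1.5 nM to 7 nM.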

Compound 4, half-maximal inhibitory concentration: 2 nM
Beside the measured number, compound 4's estimate is 1.5-fold (0.18 log units) above it; measured number inside the range.
By their numbers in this assay, from the lowest: compounds 1 and 4 (each within the scatter of the next); then compounds 3 and 2 (each within the scatter of the next).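

In this assay, phenoxymethyl in place of benzyloxy on the ester chain leaves the number unmoved (no change at the digits printed from compound 1 to compound 4 (within the scatter)), so this position accepts both chain ethers equally. 2-Phenoxyethyl in place of the group of 11 heavy atoms, with its five-membered non-aromatic ring, recovers the earlier loss (a 3.5-fold lower number from compound 3 to compound 4 (0.54 log units; beyond the scatter)), which shows that this loss belongs to that group and not to the ester chain as such. 4-Phenoxybutoxy in place of (3-phenoxypropyl)amino also lowers the number (a 4.5-fold lower number from compound 2 to compound 4 (0.65 log units; beyond the scatter)), but this step changes the link and the chain together, so neither can be credited alone.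

Still open, from the compounds shown here alone, is whether an amine, a carboxylic acid or a longer chain in place of the phenoxy group would hold the number at this level. No supporting data accompany these compounds to explain the differences.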